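A Difluorobenzyl Follow-Up to Compound 3

This account rests on a few compounds, and the source may have more. Where it says the series, first, only, none or still open, it means among the compounds named here.

Measured in a functional assay on MCF7 cells (Homo sapiens) for inhibition, read by MTT assay, with a stated time of 48 h; a higher number here means a weaker inhibitor, a lower number a stronger inhibitor:
- Compound 1 `Fc1ccccc1CSc1nnc(-c2ccncc2)n1-c1ccccc1`: > 50000 nM, a limit of the assay
- Compound 2 `Clc1ccc(CSc2nnc(-c3ccncc3)n2-c2ccccc2)cc1`: 13300 nM
- Compound 3 `Brc1ccc(CSc2nnc(-c3ccncc3)n2-c2ccccc2)cc1`: 12600 nM

For the measured compounds named here, compound 3 and compound 2 hold the only two numeric values, and they cannot be told apart, with a 1.1-fold lower number from compound 2 to compound 3 (0.02 log units; within the scatter).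

The next compound, compound 4 `Fc1ccc(CSc2nnc(-c3ccncc3)n2-c2ccccc2)c(F)c1`, differs from compound 3 by 2,4-difluorophenyl in place of 4-bromophenyl on a saturated chain carbon bound to a sulfur. The closest evidence comes from the two measured changes away from the 2-fluorophenyl group, namely an at least 3.9-fold lower number from compound 1 to compound 3 (0.59 log units; beyond the scatter) and an at least 3.7-fold lower number from compound 1 to compound 2 (0.57 log units; beyond the scatter). As far as these compounds go, both rest on a limit, so their true size is unknown. Compound 4 keeps a fluorine-bearing ring and lacks the 4-bromophenyl group, so a move back towards higher numbers in this assay is expected, of about the same size as those steps or smaller. The expected change is a 2.4-fold higher number from compound 3 to compound 4 (0.38 log units; beyond the scatter). For compound 4 the estimated value is 30000 nM, with an expected range of 12000 nM to 50000 nM.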

Compound 4, half-maximal inhibitory concentration: 14100 nM
The estimate for compound 4 lay 2.1-fold (0.33 log units) above the measured number; the measured number falls inside the stated range.
By their numbers in this assay, from the lowest: compounds 3, 2 and 4 (each within the scatter of the next). At a limit, above all of these: compound 1.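

In this assay, the 2,4-difluorophenyl group on a saturated chain carbon bound to a sulfur cannot be told apart from the two groups it was compared with, with a 1.1-fold higher number from compound 3 to compound 4 (0.05 log units; within the scatter) and a 1.1-fold higher number from compound 2 to compound 4 (0.03 log units; within the scatter). A fluorine-bearing ring can therefore give a number level with those of the 4-bromophenyl and 4-chlorophenyl compounds, and fluoro in place of hydrogen on an aromatic carbon is enough to give an at least 3.5-fold lower number from compound 1 to compound 4 (0.54 log units; beyond the scatter). Compound 1 stands at a limit and not a number, so the true size of that step is unknown: the limit of > 50000 nM in this assay, at which 1 of the 4 values shown sits.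

The compounds shown leave open whether a methoxy group or a nitrile on this phenyl ring, or an amine in its place, would give a number clearly apart from those of compound 2, compound 3 and compound 4. They also leave open how far a change to the shared core would move these numbers.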